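The source may hold more compounds than are shown below. What is called first, only, known or untested is meant among the compounds shown, and "the series" means these compounds.

Compound 1, `COCCOC(=O)c1c(-c2ccc(OC)c(OC)c2)csc1N`, gives 57% in an assay on isolated protein for inhibition of protein kinase C zeta type (Homo sapiens), with stated times of 1 h and 2.5 min, tested at 30 uM; a lower number here means less inhibition, a higher number more inhibition at the concentration tested (going by the name of the read-out).
Compound 2, `COc1ccc(-c2csc(N)c2C(=O)OCc2cccc(C)c2)cc1OC`, gives 67%.
Compound 3, `COc1ccc(-c2csc(N)c2C(=O)OCc2ccc(C)cc2)cc1OC`, gives 50%.

All three share one core and differ in one place. Compound 3 stands lowest of the three numbers, but its gap to compound 1 is within the scatter (a number 7 percentage points lower from compound 1 to compound 3 (within the scatter)), while the step of a number 17 percentage points lower from compound 2 to compound 3 (beyond the scatter) lies beyond it. Compound 4, `COc1ccc(-c2csc(N)c2C(=O)OCc2ccc(F)cc2)cc1OC`, is compound 3 with one change: fluoro in place of methyl on an aromatic carbon. For the measured compounds named here, no measured step touches this position; the steps of a number 10 percentage points higher from compound 1 to compound 2 (within the scatter), a number 7 percentage points lower from compound 1 to compound 3 (within the scatter) and a number 17 percentage points lower from compound 2 to compound 3 (beyond the scatter) all concern the group on the saturated chain carbon bound to oxygen, and two of them lie within the scatter. Compound 4 is therefore expected to show no change at the digits printed from compound 3 to compound 4 (within the scatter), a step not beyond the scatter. The estimate for compound 4 is 50%, ranging from 30% to 70%.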

Compound 4, a percentage reported as inhibition, at one concentration (the size of the read-out at that concentration, not a potency): 2%
Compound 4: middle estimate off by 48 percentage points, on the high side, and the stated range ends above it.
By their numbers in this assay, from the lowest: compound 4; then compounds 3, 1 and 2 (each within the scatter of the next, the first and the last beyond it).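

Swapping methyl for fluoro on the aromatic carbon para to a large group, a change of one heavy atom, gives a number 48 percentage points lower from compound 3 to compound 4 (beyond the scatter) in this assay, so this place matters far more than the earlier compounds could show. The 4-fluorophenyl group also compares poorly with the other two groups, with a number 65 percentage points lower from compound 2 to compound 4 (beyond the scatter) and a number 55 percentage points lower from compound 1 to compound 4 (beyond the scatter). Nothing measured here accounts for this fall.

On these data alone, how chloro, a hydroxyl or an amine would read at this same place stays open, and so does whether the fall belongs to fluoro alone.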